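Swapping the end group on the chain of compound 3

The source may hold more compounds than are shown below. What is called first, only, known or untested is meant among the compounds shown, and "the series" means these compounds.

Measured in an ADME assay on HEK293 cells (Homo sapiens) for inhibition, read by MTT assay, with a stated time of 3 days; a lower number here means a stronger inhibitor, a higher number a weaker inhibitor:
compound 1 `COc1ccc(/C=C\c2cc(OC)c(OC)c(OC)c2)cc1OCc1ccccc1` 15000 nM
compound 2 `COc1ccc(/C=C\c2cc(OC)c(OC)c(OC)c2)cc1OCc1ccc(Br)cc1` 45000 nM
compound 3 `COCOc1ccccc1/C=C/CCCOc1cc(/C=C\c2cc(OC)c(OC)c(OC)c2)ccc1OC` 106000 nM

Of these three, compound 3 has the highest number, 106000 nM, and so is the weakest inhibitor. Compound 4 `COc1ccc(/C=C\c2cc(OC)c(OC)c(OC)c2)cc1OCCC/C=C/c1ccc(Br)cc1` differs from it in one place: 4-bromophenyl in place of 2-(methoxymethoxy)phenyl on a double-bonded chain carbon bound to a double-bonded chain carbon. Within the data shown here, the only measured step that bears on this is a 3.0-fold higher number from compound 1 to compound 2 (0.48 log units; beyond the scatter), a modest one with bromo in place of hydrogen on an aromatic carbon. Among the measured compounds shown here, no measured step covers the loss of the 2-(methoxymethoxy)phenyl, so neither direction can be favoured, and no step beyond the scatter is expected in this assay. The expected change is a 1.3-fold lower number from compound 3 to compound 4 (0.12 log units; within the scatter). For compound 4 the estimate is 80000 nM, with an expected range of 25000 nM to 200000 nM.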

Compound 4, half-maximal inhibitory concentration: 55000 nM
Beside the measured number, compound 4's estimate is 1.5-fold (0.16 log units) above it; the measured number falls inside the stated range.
By their numbers in this assay, from the lowest: compound 1; then compounds 2, 4 and 3 (each within the scatter of the next, the first and the last beyond it).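

In this assay, 4-bromophenyl in place of 2-(methoxymethoxy)phenyl on the chain gives a 1.9-fold lower number from compound 3 to compound 4 (0.28 log units; within the scatter), so this exchange of end group, with its fewer heavy atoms and no hydrogen-bond acceptors, does not move the number beyond the scatter. Among these compounds, the whole group of 11 heavy atoms in place of the group of 7 gives a 1.2-fold higher number from compound 2 to compound 4 (0.09 log units; within the scatter), while in place of the group of 6 it gives a 3.7-fold higher number from compound 1 to compound 4 (0.56 log units; beyond the scatter), and only this last step lies beyond the scatter. No evidence bearing on these numbers is at hand.

The compounds shown leave open how an amine or a carboxylic acid at the end of this chain would read in this assay. They also leave open whether a longer chain carrying 4-bromophenyl would stay within the scatter of compound 4.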